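Swapping a Nitrile for Trifluoromethoxy on an Arylpiperazine

The source may report more compounds than this note shows. Statements on the series, on what has been measured and on what is new or still open speak of the compounds shown alone.

Measured compounds:
Compound 1, `COc1ccccc1N1CCN(CCCNc2ncccc2C(=O)NC(C)(C)C)CC1`, 1.26 nM
Compound 2, `COc1ccccc1N1CCN(CCCNc2cncnc2C(=O)N(C)C)CC1`, 3.98 nM
Compound 3, `CN(C)C(=O)c1cccnc1NCCCN1CCN(c2ccccc2C#N)CC1`, 2 nM

Of the compounds shown here, three have been tested in a functional assay for antagonist activity at Alpha-1A adrenergic receptor (Oryctolagus cuniculus); a higher number here means weaker binding, a lower number tighter binding. All three share a piperazine carrying a substituted phenyl ring on one nitrogen and a three-carbon chain on the other, ending in an amino-substituted aromatic amide. In this assay compound 3 gives 2 nM, which is the second highest of the three numbers. Compound 1 sits closest, at a slightly lower number, and compound 2 is furthest, at a somewhat higher number, but both gaps lie within the usual scatter of repeated measurements, so the three compounds cannot be told apart on these data.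

Compound 4, `CN(C)C(=O)c1cccnc1NCCCN1CCN(c2ccccc2OC(F)(F)F)CC1`, has not yet been measured. It differs from compound 3 in one place: trifluoromethoxy in place of cyano on an aromatic carbon. For the measured compounds named here, no measured pair shows this exact change, so its effect is not known from the data. Because compound 3 gives 2 nM and all three measured compounds fall in a narrow band, compound 4 is expected to stay close to compound 3, with a step of a 1.5-fold higher number from compound 3 to compound 4 (0.18 log units; within the scatter) no larger than the scatter in either direction. Compound 4 is therefore estimated at 3 nM, within a range from 1 nM to 10 nM.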

Compound 4, dissociation constant: 3.16 nM
Beside the measured number, compound 4's estimate is 1.1-fold (0.02 log units) below it; low and high end bracket the measured number.
By their numbers in this assay, from the lowest: compounds 1, 3, 4 and 2 (each within the scatter of the next, the first and the last beyond it).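

For the compounds shown here, this is the first pair here that differs in one place only, so it gives the first direct reading of a change on this aromatic carbon, ortho to a large group, in this assay. Putting trifluoromethoxy, with 5 heavy atoms, in place of cyano, with 2 heavy atoms, gives a 1.6-fold higher number from compound 3 to compound 4 (0.20 log units; within the scatter), so the two compounds cannot be told apart and this position tolerates the bigger group on these data. Nothing available explains why these two groups read alike.

The compounds shown leave open whether a very different group on this same carbon, such as an amine or a carboxylic acid, would also read alike in this assay, as this single pair covers only two groups. They also leave open whether the same swap would give a similarly small step on another core, such as the core of compound 2.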